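From 3,4-Difluorophenyl to 3-Fluoro-4-methoxyphenyl: An Expectation

A few compounds are considered here, and "the series" means these few. Any claim that something is new, unique, unknown or untested is made for them only; others in the source may bear on it.

Compound 1, `COc1cc(-c2cc(/C=C/C(=O)c3ccccc3)[nH]n2)cc(OC)c1OC`: 2300 nM
Compound 2, `COc1cc(-c2cc(/C=C/C(=O)c3ccc(F)c(F)c3)[nH]n2)cc(OC)c1OC`: 1500 nM

Of the compounds shown here, two built on the same core have been tested. In a functional assay on MDA-MB-231 cells (Homo sapiens) for inhibition, read by MTT assay, with a stated time of 48 h (a lower number here means a stronger inhibitor, a higher number a weaker inhibitor), compound 1 gives 2300 nM, and compound 2 gives 1500 nM. For the measured compounds named here, the only step between them, a 1.5-fold lower number from compound 1 to compound 2 (0.19 log units; within the scatter), is small enough to sit inside the ordinary spread of repeated measurements. Compound 2 therefore carries the lower of the two numbers, but since its nearest neighbour, compound 1, lies within the scatter, neither compound can be called the stronger inhibitor on this evidence.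

Compound 3, `COc1ccc(C(=O)/C=C/c2cc(-c3cc(OC)c(OC)c(OC)c3)n[nH]2)cc1F`, has not yet been measured. It differs from compound 2 by methoxy in place of fluoro on an aromatic carbon. Going by the values given here, the single measured step bears on it only loosely: it changed phenyl to 3,4-difluorophenyl and moved the number within the scatter, whereas here one fluoro gives way to methoxy. Among the compounds with values here, no measured pair tests a methoxy at this place, so there is no ground for expecting a large change in either direction. The expected step from compound 2 to compound 3 is accordingly estimated as a 1.4-fold lower number from compound 2 to compound 3 (0.13 log units; within the scatter), a shift within the scatter. Compound 3 is expected to give about 1100 nM in this assay, with a likely range from 350 nM to 3500 nM.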

Compound 3, half-maximal inhibitory concentration: 2700 nM
Beside the measured number, compound 3's estimate is 2.5-fold (0.39 log units) below it; measured number inside the range.
By their numbers in this assay, from the lowest: compounds 2, 1 and 3 (each within the scatter of the next).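

For the compounds shown here, this is the first measured pair to test methoxy on this aromatic carbon, ortho to a fluoro group and para to a large group: methoxy in place of fluoro gives a 1.8-fold higher number from compound 2 to compound 3 (0.26 log units; within the scatter) in this assay, so the two groups cannot be told apart at this place. Set against the unsubstituted phenyl, the whole 3-fluoro-4-methoxyphenyl group gives a 1.2-fold higher number from compound 1 to compound 3 (0.07 log units; within the scatter), which means that neither substituted ring shown so far can be separated from plain phenyl, and every step among these compounds stays within the ordinary spread of repeated measurements. No independent measurement bears on this result, so nothing can be said about what lies behind it.

The compounds shown carry only fluoro and methoxy on this carbon, so it remains open whether an amine, a carboxylic acid or a longer alkoxy chain here would give a number clearly apart from these. It also remains open whether the fluoro group ortho to this carbon matters, as the compounds shown offer no pair that changes that group alone while methoxy stays in place.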